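The source may hold more compounds than are shown below. What is called first, only, known or untested is meant among the compounds shown, and "the series" means these compounds.

Measured so far in an assay on U2OS cells for activation of nuclear factor erythroid 2-related factor 2 (Homo sapiens), read by chemiluminescence, with a stated time of 6 h; on this read-out lower numbers stand for an effect already at smaller amounts and higher numbers for an effect only at larger amounts of compound:

- Compound 1, `COc1ccccc1S(=O)(=O)/C=C/c1cccc(Cl)n1`: 1160 nM
- Compound 2, `COc1ccccc1S(=O)(=O)/C=C/c1ccc(Cl)cn1`: 6310 nM
- Compound 3, `COc1cccc(S(=O)(=O)/C=C/c2ccccn2)c1`: 2170 nM

Among these three numbers compound 3 stands second highest. Its nearest neighbour is compound 1, whose number is lower but still within the usual scatter, so the two cannot be told apart with confidence. Its furthest neighbour is compound 2, whose number is higher by a margin beyond the scatter, so compound 3 is clearly the better of that pair in this assay.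

Compound 4, `COc1cccc(S(=O)(=O)/C=C/c2cccc(Cl)n2)c1`, has not been measured. It differs from compound 3 in one place: chloro in place of hydrogen on an aromatic carbon. Going by the values given here, no pair of measured compounds shows this exact change on its own, so the expectation can only lean on the wider picture. The chloro sitting next to the ring nitrogen is present in compound 1, which in this assay gives 1160 nM, while the same group moved elsewhere on that ring in compound 2 gives 6310 nM. On that basis a small move toward lower numbers, probably not beyond the scatter, is expected: a 1.7-fold lower number from compound 3 to compound 4 (0.22 log units; within the scatter). Compound 4 is therefore estimated at 1300 nM, with a likely range from 500 nM to 3500 nM.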

Compound 4, half-maximal effective concentration: 786 nM
Compound 4: middle estimate off by 1.7-fold (0.22 log units), on the high side; measured number inside the range.
By their numbers in this assay, from the lowest: compounds 4, 1 and 3 (each within the scatter of the next, the first and the last beyond it); then compound 2.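

In this assay, replacing hydrogen with chloro on the aromatic carbon next to the ring nitrogen gives a 2.8-fold lower number from compound 3 to compound 4 (0.44 log units; beyond the scatter), a modest step but one beyond the scatter. Going by these compounds alone, this is the first pair here that differs in one place only, so the effect of this change at this position can be read directly instead of being inferred from compounds that differ in more than one way. The data offer no measurement that explains the shift.

Going by these compounds, it remains open whether a different group in the same place, such as fluoro, bromo, methyl or an amine, would lower the number as chloro does, or whether this result is specific to chloro. On these data alone, it is also open whether chloro would give a step of similar size on the core of compound 1, which would need a partner of compound 1 carrying hydrogen in that place.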